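The source may hold more compounds than are shown below. What is called first, only, known or untested is meant among the compounds shown, and "the series" means these compounds.

Compound 1 `CN(C)CCn1c(N)c(-c2nc3ccccc3n2C)c2nc(C#N)c(C#N)nc21`, tested in a functional assay on A549 cells (Homo sapiens) for antiproliferative activity, read by MTT assay, with a stated time of 48 h (a lower number here means a stronger inhibitor, a higher number a weaker inhibitor), reports only a limit, > 50000 nM. Compound 2 `CCN(CC)CCCn1c(N)c(-c2nc3ccccc3n2C)c2nc(C#N)c(C#N)nc21` gives 10700 nM and compound 3 `CCN(CC)CCCCn1c(N)c(-c2nc3ccccc3n2C)c2nc(C#N)c(C#N)nc21` gives 1720 nM. Compound 2 therefore holds the higher of the two actual numbers, and compound 3 is its nearest neighbour. Compound 4 `CCN(CC)CCCn1c(N)c(-c2nc3cc(Cl)ccc3[nH]2)c2nc(C#N)c(C#N)nc21` keeps the 3-(diethylamino)propyl group of compound 2 and differs in one place: 5-chloro-1H-benzimidazol-2-yl in place of 1-methyl-1H-benzimidazol-2-yl on an aromatic carbon. There, 5-chloro-1H-benzimidazol-2-yl stands in place of 1-methyl-1H-benzimidazol-2-yl on an aromatic carbon, next to the ring atom that bears an amino group.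

All three measured steps lie on the saturated chain: an at least 4.6-fold lower number from compound 1 to compound 2 (0.66 log units; beyond the scatter), an at least 29-fold lower number from compound 1 to compound 3 (1.46 log units; beyond the scatter) and a 6.2-fold lower number from compound 2 to compound 3 (0.79 log units; beyond the scatter). None of them touches the aromatic carbon changed here, so they indicate only how far a single change has moved the numbers in this series. The closest guide is a 6.2-fold lower number from compound 2 to compound 3 (0.79 log units; beyond the scatter), a modest step that starts from compound 2 itself. Among the measured compounds shown here, a modest step toward a lower number in this assay is therefore expected, although the direction remains tentative, as no measured compound carries the entering group. The expected step is a 3.1-fold lower number from compound 2 to compound 4 (0.49 log units; beyond the scatter). For compound 4 the estimated value is 3500 nM, with an expected range of 700 nM to 17000 nM.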

Compound 4, half-maximal inhibitory concentration: > 50000 nM
Compound 4: a limit, no number; the forecaster's own chance of this, stated with the estimate: 5%; at least 14-fold (1.15 log units) between middle value and limit.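

In this assay, 5-chloro-1H-benzimidazol-2-yl in place of 1-methyl-1H-benzimidazol-2-yl gives an at least 4.6-fold higher number from compound 2 to compound 4 (0.66 log units; beyond the scatter), so a change on this aromatic carbon, next to the ring atom that bears an amino group, moves the read-out in the opposite direction to the step from compound 2 to compound 3 on the saturated chain. The value of compound 4 is a limit and not a number, so the step gives a direction and a minimum size, with its full size unread: the limit of > 50000 nM in this assay, at which 2 of the 4 values shown sit. The entering group carries a chlorine and a hydrogen-bond donor that the leaving group lacks, and this single step changes both at once, so it cannot assign the loss to either.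

The compounds shown leave open how the unsubstituted 1H-benzimidazol-2-yl group or 5-chloro-1-methyl-1H-benzimidazol-2-yl would read at this position, and either would separate the chlorine from the ring methyl. They also leave open whether 5-chloro-1H-benzimidazol-2-yl would give the same result on the longer chain of compound 3.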